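Exchanging the acid of compound 2 for a primary amide

The compounds below may be only part of what the source reports. "The series", "measured", "known", "first", "only" and "open" are said of these compounds alone.

Within the data shown here, compound 2 `Cc1nc(-c2ccc(C(F)(F)F)cc2)sc1CNc1ccc(CC(C)C(=O)O)cc1` gives 355 nM in a functional assay on CHO cells for agonist activity at Free fatty acid receptor 1 (Homo sapiens) (on this read-out lower numbers stand for an effect already at smaller amounts and higher numbers for an effect only at larger amounts of compound), the highest of the two numbers measured so far. Among the measured compounds shown here, its nearest neighbour is compound 1 `Cc1nc(-c2ccc(C(F)(F)F)cc2)sc1CNc1ccc(/C=C/C(=O)O)cc1`, which in this assay gives 36.3 nM; that pair differs only in the side chain, and the step of a 9.8-fold higher number from compound 1 to compound 2 (0.99 log units; beyond the scatter) is the only measured step in the set. Compound 3 `Cc1nc(-c2ccc(C(F)(F)F)cc2)sc1CNc1ccc(CCC(N)=O)cc1` is built from compound 2 by the change (carbamoylmethyl in place of 1-carboxyethyl on a saturated chain carbon bound to an aromatic carbon). For the measured compounds named here, the measured step from compound 1 to compound 2 concerns the chain that carries the acid, not the acid itself, so it bears on compound 3 only indirectly; no measured pair shows what happens when the carboxylic acid shared by compounds 1 and 2 is lost. The expectation is therefore uncertain, and with no acid left in compound 3 the number is expected to move to a higher value, a step of a 9.9-fold higher number from compound 2 to compound 3 (0.99 log units; beyond the scatter). Compound 3 is estimated to give 3500 nM in this assay, within a range from 500 nM to 25000 nM.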

Compound 3, half-maximal effective concentration: 12.9 nM
Compound 3: the middle estimate sits 270-fold (2.43 log units) above what was measured; measured number below the stated range.
By their numbers in this assay, from the lowest: compound 3; then compound 1; then compound 2.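

A carboxylic acid on this chain proves not to be required for a low number in this assay: the primary amide of compound 3, carried as 2-carbamoylethyl, replaces the 2-carboxypropyl of compound 2 and gives a large step in the favourable direction (a 28-fold lower number from compound 2 to compound 3 (1.44 log units; beyond the scatter)). The amide also goes past the acid with the 2-carboxyethenyl chain, by a modest step (a 2.8-fold lower number from compound 1 to compound 3 (0.45 log units; beyond the scatter)), which leaves compound 3 with the lowest number of the three, so among these compounds the acid is not what sets the low end of the series. Nothing available explains why the amide does so well in this functional read-out.

The change from compound 2 to compound 3 removes the methyl branch on the chain and replaces the carboxylic acid in a single step, so the compounds shown do not divide the gain between those two parts. As far as these compounds go, a 2-carboxyethyl chain or a 2-carbamoylpropyl chain on the same core would separate them, and whether a secondary amide or a nitrile keeps the low number also remains open.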